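This account rests on a few compounds, and the source may have more. Where it says the series, first, only, none or still open, it means among the compounds named here.

Compound 3 `N#Cc1c(NCc2ccccc2)c(F)c2nc(N)nc(N)c2c1F` stands at the top of the series in a functional assay on A549 cells (Homo sapiens) for cytotoxicity, read by MTT assay; a higher number here means a weaker inhibitor, a lower number a stronger inhibitor: compound 3 gives > 1000 ug/mL, a limit of the assay rather than a number. Compound 1 `N#Cc1c(Nc2ccccc2)c(F)c2nc(N)nc(N)c2c1F` also gives a limit, > 1000 ug/mL. Compound 2 `N#Cc1c(Nc2ccc(Cl)cc2)c(F)c2nc(N)nc(N)c2c1F` gives 115 ug/mL. The readable steps are an at least 8.6-fold lower number from compound 1 to compound 2 (0.93 log units; beyond the scatter) and an at least 8.6-fold higher number from compound 2 to compound 3 (0.93 log units; beyond the scatter); the step that the two limits leave unreadable from compound 1 to compound 3 cannot be sized, because of the limit of > 1000 ug/mL in this assay, at which 2 of the 3 values shown sit. Compound 4 `CC(C)(C)Nc1c(C#N)c(F)c2c(N)nc(N)nc2c1F` differs from compound 3 by tert-butyl in place of benzyl on a nitrogen on an aromatic ring. Going by the values given here, no measured step swaps a benzyl for an alkyl on this nitrogen, so none bears directly on it; the only sizable steps involve the chloro on the ring. Compound 3 already sits at the limit, so the expected step is a number no higher from compound 3 to compound 4 (the limit leaves the size open), within the scatter. Compound 4 is therefore estimated at 1000 ug/mL, with a range of 300 ug/mL to 1500 ug/mL.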

Compound 4, half-maximal inhibitory concentration: > 1000 ug/mL
Compound 4 was reported as a limit; the forecaster's own chance of this, stated with the estimate: 65%; the middle value sits exactly at the limit.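

In this assay, compound 4 gives > 1000 ug/mL, a limit and not a number, so a tert-butyl with no ring on this nitrogen sits at the same limit as the ring-bearing benzyl and phenyl groups. Of the groups shown, only 4-chlorophenyl gives a readable number, with an at least 8.6-fold higher number from compound 2 to compound 4 (0.93 log units; beyond the scatter). The steps from compound 1 and compound 3 to compound 4 cannot be read: the limit of > 1000 ug/mL in this assay, at which 3 of the 4 values shown sit.

Still open, as far as these compounds go, is whether a chloro on the benzyl group of compound 3 would give a readable number. Also open, from the compounds shown here alone, is whether a longer alkyl chain or a chain carrying an amine on this nitrogen would do so.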